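Plasma stability of the series: fluoro analogue of compound 1

This account rests on a few compounds, and the source may have more. Where it says the series, first, only, none or still open, it means among the compounds named here.

Measured compounds:
Compound 1, `Cc1c(OCCCCOc2ccc(C(=O)O)cc2)ccc(C(=O)CC(C)C)c1O`: 95%
Compound 2, `COc1ccc(C(=O)O)cc1OCCCCOc1ccc(C(=O)CC2CCCC2)c(O)c1C`: 103%
Compound 3, `Cc1c(OCCCCOc2ccc(C(=O)O)c(Cl)c2)ccc(C(=O)CC2CCCC2)c1O`: 97%

In an ADME assay on a cell-free system (plasma, Rattus norvegicus) for metabolic stability, read by LC-MS, with a stated time of 60 min, tested at 100 uM (a lower number here means that less of the compound is left, a higher number that more of the compound is left), compound 1 gives 95%; compound 3 gives 97% and compound 2 gives 103%, and all three numbers lie within the usual scatter of one another, so compound 1 cannot be told apart from the other two on this read-out.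

Compound 4, `Cc1c(OCCCCOc2ccc(C(=O)O)cc2F)ccc(C(=O)CC(C)C)c1O`, differs from compound 1 by fluoro in place of hydrogen on an aromatic carbon, the 4-carboxyphenyl becoming 4-carboxy-2-fluorophenyl. Among the compounds with values here, the one measured step that changes the aryl ring on the oxygen is a number 6 percentage points lower from compound 2 to compound 3 (within the scatter), which brings a chloro in and a methoxy out yet stays within the scatter. Within the data shown here, no measured step with a fluoro alone exists, so the expectation rests on that step. The step of no change at the digits printed from compound 1 to compound 4 (within the scatter) is therefore expected to stay within the scatter. Compound 4 is estimated at 95%, with a range from 84% to 106%.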

Compound 4, percent of the compound remaining: 106%
For compound 4 the middle estimate is 11 percentage points below the measured one; measured number inside the range.
By their numbers in this assay, from the lowest: compounds 1, 3, 2 and 4 (each within the scatter of the next, the first and the last beyond it).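

In this assay, fluoro in place of hydrogen on an aromatic carbon, ortho to a large group and meta to a carboxy group, gives a number 11 percentage points higher from compound 1 to compound 4 (beyond the scatter). Within the data shown here, this is the first step beyond the scatter, whereas the earlier aryl change, a number 6 percentage points lower from compound 2 to compound 3 (within the scatter), stayed within it. So this place on the ring can register a single-atom change on this read-out, and nothing available explains the shift. Open, going by these compounds, is how a nitrile or a trifluoromethyl at this place would read, and whether the fluoro step carries over to the side chain of compound 3.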